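The source may report more compounds than this note shows. Statements on the series, on what has been measured and on what is new or still open speak of the compounds shown alone.

Among the measured compounds shown here, in a functional assay on MCF7 cells (Homo sapiens) for inhibition, read by CCK-8 assay, with a stated time of 48 h (on this read-out lower numbers stand for stronger inhibition of growth and higher numbers for weaker inhibition of growth), compound 1 `Cc1ccccc1Nc1nc(Nc2ccc(N3CCN(C)CC3)cn2)ncc1Cl` gives 5210 nM and stands lowest of the two numbers so far, while compound 3 `Cc1ccccc1Nc1nc(Nc2ccc(N3CCCCC3)cn2)ncc1Cl` gives 21400 nM as the only other number. Compound 2 `CCN1CCN(c2ccc(Nc3ncc(Cl)c(Nc4ccccc4C)n3)nc2)CC1` gives > 100000 nM as a limit of the assay and not a number. Compound 4 `CN1CCN(c2ccc(Nc3ncc(Cl)c(Nc4ccccc4)n3)nc2)CC1` carries hydrogen in place of methyl on an aromatic carbon in the 2-methylphenyl group. For the measured compounds named here, no measured step touches this place: both a 4.1-fold higher number from compound 1 to compound 3 (0.61 log units; beyond the scatter) (modest) and an at least 19-fold higher number from compound 1 to compound 2 (1.28 log units; beyond the scatter) (large) alter the 4-methylpiperazin-1-yl group. Only a small step toward higher numbers is therefore expected in this assay and none beyond the scatter can be firmly foreseen. The estimated change is a 1.5-fold higher number from compound 1 to compound 4 (0.19 log units; within the scatter) on present data. For compound 4 the expected value is 8000 nM with 2500 nM to 30000 nM as the estimated range.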

Compound 4, concentration for 50% growth inhibition: 51800 nM
The estimate for compound 4 lay 6.5-fold (0.81 log units) below the measured number; measured number outside the range, above it.
By their numbers in this assay, from the lowest: compound 1; then compound 3; then compound 4. At a limit, above all of these: compound 2.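

Until now, every step changed the 4-methylpiperazin-1-yl group; this one shows that the methyl on the aromatic carbon also matters for growth inhibition in this assay, with a 9.9-fold higher number from compound 1 to compound 4 (1.00 log units; beyond the scatter). Removing this single heavy atom leaves the rest of compound 1 unchanged, so the 2-methylphenyl group is a sensitive place in the series. Nothing shown here accounts for the size of this step.

On these data alone, whether an ethyl, a methoxy or a chlorine at this place would match the methyl remains open. Also open, as far as these compounds go, is whether the methyl counts as much alongside piperidin-1-yl.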